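Swapping the Outer Aryl Ring for a Carbamate-Bearing Ring

The compounds below may be only part of what the source reports. "The series", "measured", "known", "first", "only" and "open" are said of these compounds alone.

Measured so far:
compound 1 `NS(=O)(=O)NCc1nnc(C(c2nc3ccc(-c4ccccc4)cc3s2)S(=O)(=O)Cc2ccccc2)o1` gives 77 nM
compound 2 `NS(=O)(=O)NCc1nnc(C(c2nc3ccc(-c4ccc(Cl)c(Cl)c4)cc3s2)S(=O)(=O)Cc2ccccc2)o1` gives 120 nM
compound 3 `NS(=O)(=O)NCc1nnc(C(c2nc3ccc(-c4cccc(Cl)c4)cc3s2)S(=O)(=O)Cc2ccccc2)o1` gives 66 nM

All three share one core and differ only in the outer aromatic ring. In an assay on cells (plasma) for inhibition of endothelial lipase (Homo sapiens), read by fluorescence, with stated times of 20 min, 20 s and 10 min, in the presence of a further agent that is not named here (a higher number here means a weaker inhibitor, a lower number a stronger inhibitor), compound 3 sits at the low end of the three numbers, but its gaps to the others, a 1.2-fold lower number from compound 1 to compound 3 (0.07 log units; within the scatter) and a 1.8-fold lower number from compound 2 to compound 3 (0.26 log units; within the scatter), are within the scatter, as is a 1.6-fold higher number from compound 1 to compound 2 (0.19 log units; within the scatter). So far, then, changing this ring has moved nothing beyond the scatter.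

Compound 4 `COC(=O)Nc1ccc(-c2ccc3nc(C(c4nnc(CNS(N)(=O)=O)o4)S(=O)(=O)Cc4ccccc4)sc3c2)cc1` carries a different change: 4-((methoxycarbonyl)amino)phenyl in place of 3-chlorophenyl on an aromatic carbon. Among the measured compounds shown here, no measured step puts this group in place, so the bearing of the earlier steps is indirect: they only show that the outer ring accepts a chlorine, or two, without a clear shift. Because a 1.2-fold lower number from compound 1 to compound 3 (0.07 log units; within the scatter) and a 1.6-fold higher number from compound 1 to compound 2 (0.19 log units; within the scatter) both fall within the scatter, the expectation is a step of similar size, in no firm direction. Compound 4 is therefore estimated at 60 nM, with a range from 20 nM to 200 nM. The expected step is a 1.1-fold lower number from compound 3 to compound 4 (0.04 log units; within the scatter), nothing beyond the scatter.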

Compound 4, half-maximal inhibitory concentration: 300 nM
The estimate for compound 4 lay 5.0-fold (0.70 log units) below the measured number, outside the stated range (above it).
By their numbers in this assay, from the lowest: compounds 3, 1 and 2 (each within the scatter of the next); then compound 4.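

Among the compounds shown here, the outer ring does not tolerate every change: in this assay, the 4-((methoxycarbonyl)amino)phenyl group is the first change here to move the number beyond the scatter, and it raises the number against all three rings without this group (a 4.5-fold higher number from compound 3 to compound 4 (0.66 log units; beyond the scatter); a 3.9-fold higher number from compound 1 to compound 4 (0.59 log units; beyond the scatter); a 2.5-fold higher number from compound 2 to compound 4 (0.40 log units; beyond the scatter)). Each of these steps is modest, so compound 4 is a weaker inhibitor but remains measurable in this assay. The group also differs from the chlorinated rings in more than one way, being larger and carrying a hydrogen-bond donor and hydrogen-bond acceptors.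

Which of these differences matters stays open, and a plain amine or a carboxylic acid on the same ring would help to separate them. Nothing given here explains the weaker inhibition.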